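Fluorocyclopropyl amide series: stereoisomer step at the ring carbon

This account rests on a few compounds, and the source may have more. Where it says the series, first, only, none or still open, it means among the compounds named here.

Maximal response in an assay on SH-EP1 cells for agonist activity at Neuronal acetylcholine receptor; alpha4/beta2 (Homo sapiens), read by FLIPR and calcium flux; a higher number here means a larger maximal response, a lower number a smaller maximal response:
compound 1 `CC(C)C(=O)N1CC2CC(C1)N2`: 71%
compound 2 `O=C(C1CCC1)N1CC2CC(C1)N2`: 99%
compound 3 `O=C([C@H]1C[C@H]1F)N1CC2CC(C1)N2`: 110%

Compound 3 stands highest of the three in this assay, with a number 11 percentage points higher from compound 2 to compound 3 (beyond the scatter) and a number 39 percentage points higher from compound 1 to compound 3 (beyond the scatter). Compound 4 `O=C([C@H]1C[C@@H]1F)N1CC2CC(C1)N2` keeps every atom and bond of compound 3; the change is the two compounds have the same atoms and bonds; at least one stereo element is drawn with a configuration in one of them and without one in the other: 1 of 4 stereo elements differ; a stereocentre at a saturated ring carbon is drawn R in compound 3 and S in compound 4. For the measured compounds named here, no measured step bears on such a change: each of them, including a number 28 percentage points higher from compound 1 to compound 2 (beyond the scatter), swaps the group on the carbonyl carbon while keeping the rest fixed. With nothing to weigh the two configurations against each other, compound 4 is expected close to compound 3, and a number 10 percentage points lower from compound 3 to compound 4 (within the scatter) is estimated to stay within the scatter, the range held wide to both sides. Compound 4 is estimated at 100%, between 78% and 120%.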

Compound 4, largest response reached (Emax), in percent of the reference or control that the assay uses: 100%
For compound 4 middle estimate and measured number coincide at the digits printed; low and high end bracket the measured number.
By their numbers in this assay, from the lowest: compound 1; then compounds 2, 4 and 3 (each within the scatter of the next, the first and the last beyond it).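

In this assay, the change from R to S at the saturated ring carbon gives a number 10 percentage points lower from compound 3 to compound 4 (within the scatter), so this read-out does not separate the two drawn configurations. With S drawn, the 2-fluorocyclopropyl group gives a number 1 percentage points higher from compound 2 to compound 4 (within the scatter) against cyclobutyl and a number 29 percentage points higher from compound 1 to compound 4 (beyond the scatter) against isopropyl, so the gain over isopropyl holds for compound 3 and compound 4 alike. One reservation applies to the pair: the fact that one of compounds 3 and 4 is drawn with a defined configuration and the other without, at the place where they differ

Still open, from the compounds shown here alone, is whether a methyl or hydroxyl group in place of the fluorine keeps this response. Also open, going by these compounds, is whether the two configurations separate in any other read-out.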